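Benzyl on the piperidine ring of compound 1

A few compounds are considered here, and "the series" means these few. Any claim that something is new, unique, unknown or untested is made for them only; others in the source may bear on it.

Compound 1 `COc1ccc(C(C)CCN2CCCCC2)cc1` stands as the lowest of the two numbers at hand in an assay on membranes from Cerebral cortex for displacement of a labelled ligand from Sigma non-opioid intracellular receptor 1 (Cavia porcellus), read by scintillation counting, with a stated time of 120 min (a lower number here means a stronger inhibitor, a higher number a weaker inhibitor), where compound 1 gives 20 nM. For the measured compounds named here, its nearest neighbour is compound 2 `CC(CCN1CCCCC1)c1ccccc1`, which in this assay gives 46 nM; the only measured step, a 2.3-fold higher number from compound 1 to compound 2 (0.36 log units; beyond the scatter), is a modest one and comes from a hydrogen in place of methoxy on an aromatic carbon.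

Compound 3 `COc1ccc(C(C)CCN2CCC(Cc3ccccc3)CC2)cc1` differs from compound 1 at another place: benzyl in place of hydrogen on a saturated ring carbon. Going by the values given here, no measured step touches the saturated ring carbon of the six-membered non-aromatic ring with one nitrogen, so nothing among the two measured compounds bears directly on this change. Among the compounds with values here, the single known step concerns the methoxy group and leaves the question open. What can be said is that compound 1 is already the lowest number seen, and the change adds a large group rather than removing one. On that footing a step of a 2.5-fold lower number from compound 1 to compound 3 (0.40 log units; beyond the scatter) is expected in this assay, in the direction of a lower number, of a size that may or may not clear the scatter. Compound 3 is therefore estimated at 8 nM in this assay, within a range from 2 nM to 40 nM.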

Compound 3, inhibition constant: 3.5 nM
For compound 3 the middle estimate is 2.3-fold (0.36 log units) above the measured one, and the stated range covers the measured number.
By their numbers in this assay, from the lowest: compound 3; then compound 1; then compound 2.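

Benzyl in place of hydrogen on a saturated ring carbon, three ring bonds from the ring nitrogen, is the first change at this position to be shown, and in this assay it gives a 5.7-fold lower number from compound 1 to compound 3 (0.76 log units; beyond the scatter). The methoxy group and the chain are the same in both compounds, so this step belongs to the ring position alone, and it shows that this carbon can carry a group of 7 heavy atoms with a six-membered aromatic ring while the number still falls, beyond the scatter, rather than rises. The data offer no measurement that accounts for this fall at the ring carbon.

The compounds shown leave open whether a smaller group on the same carbon, such as methyl, would move the number in the same direction, and whether phenyl, with no carbon link to the ring, or phenylethyl, with a longer chain, would do as well as benzyl. They also leave open whether benzyl would lower the number to a similar extent on the core of compound 2, which has hydrogen in place of the methoxy group.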